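The source may hold more compounds than are shown below. What is called first, only, known or untested is meant among the compounds shown, and "the series" means these compounds.

Compound 1 `CNC(=O)c1cc(C(=O)NC2CC2)cn(Cc2ccc(C)cc2)c1=O`: 24 ug/mL
Compound 2 `CNC(=O)c1cc(C(=O)NC2CC2)cn(Cc2cccc3cn[nH]c23)c1=O`: >= 181 ug/mL, a limit
Compound 3 `CNC(=O)c1cc(C(=O)NC2CC2)cn(Cc2cccc(OC)c2)c1=O`: 79 ug/mL

All three compounds were measured in a physicochemical assay for solubility; on this read-out lower numbers stand for lower solubility and higher numbers for higher solubility. Of the two that have an exact number, compound 3 stands higher at 79 ug/mL, while compound 1 gives 24 ug/mL. The reading for compound 2 is only a limit, >= 181 ug/mL.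

Compound 4 `CNC(=O)c1cc(C(=O)NC2CC2)cn(Cc2cccc3c2CCN3)c1=O` has not yet been measured. It differs from compound 3 as follows: 2,3-dihydro-1H-indol-4-yl in place of 3-methoxyphenyl on a saturated chain carbon bound to an aromatic nitrogen. In words, 2,3-dihydro-1H-indol-4-yl takes the place of 3-methoxyphenyl on a saturated chain carbon bound to an aromatic nitrogen.

Three measured steps at this same place bear on the change. The group swaps gave a 3.3-fold higher number from compound 1 to compound 3 (0.52 log units; beyond the scatter) and an at least 7.5-fold higher number from compound 1 to compound 2 (0.87 log units; beyond the scatter), while replacing 1H-indazol-7-yl with 3-methoxyphenyl gave an at least 2.2-fold lower number from compound 2 to compound 3 (0.36 log units; beyond the scatter). Among the compounds with values here, the 1H-indazol-7-yl of compound 2 is the only measured group with a second ring, as the entering group has, and it carries the top reading, >= 181 ug/mL, which is a limit. This single case favours a rise only weakly, so no step beyond the scatter is expected. The estimated step is a 1.4-fold higher number from compound 3 to compound 4 (0.14 log units; within the scatter). In this assay, compound 4 is expected at 110 ug/mL, with an estimated range of 40 ug/mL to 230 ug/mL.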

Compound 4, solubility: >= 184 ug/mL
Compound 4: no number, only a limit (the forecaster's own chance of this, stated with the estimate: 25%); middle value at least 1.6-fold (0.22 log units) from the limit.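

In this assay, the 2,3-dihydro-1H-indol-4-yl group on a saturated chain carbon bound to an aromatic nitrogen gives an at least 2.3-fold higher number from compound 3 to compound 4 (0.36 log units; beyond the scatter), and an at least 7.6-fold higher number from compound 1 to compound 4 (0.88 log units; beyond the scatter). The earlier single case now has a second example: both groups with a second ring give limits, while the one-ring groups of compound 1 and compound 3 give exact numbers. The reading for compound 4 is a limit, and the step to compound 2 cannot be read: the limit of >= 184 ug/mL in this assay, at which 1 of the 4 values shown sits.

As far as these compounds go, how far compound 2 and compound 4 truly lie beyond their limits stays open. So does whether the second ring alone carries the rise or its nitrogen takes part, which a 2,3-dihydro-1H-inden-4-yl group, with carbon in place of that nitrogen, could separate.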